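This account rests on a few compounds, and the source may have more. Where it says the series, first, only, none or still open, it means among the compounds named here.

Compound 1 `CCCS(=O)(=O)Nc1ccc(F)c(C(=O)c2n[nH]c3ncc(-c4ccccc4)cc23)c1F`: in an assay for binding affinity to dual specificity mitogen-activated protein kinase kinase 4 (Homo sapiens), read by KINOMEscan, tested at 100 nM (a higher number here means a weaker effect of the compound at the concentration tested, a lower number a stronger effect), compound 1 gives 2.4%. Compound 2 `CCCS(=O)(=O)Nc1ccc(F)c(C(=O)c2n[nH]c3ncc(-c4ccccc4Cl)cc23)c1F`: in this assay compound 2 gives 9.3%.

Compound 2 has the higher of the two numbers, and its nearest neighbour is compound 1; the step of a number 6.9 percentage points higher from compound 1 to compound 2 (within the scatter) lies within the scatter, so the two values cannot be ordered. Compound 3 `CCCS(=O)(=O)Nc1ccc(F)c(C(=O)c2n[nH]c3ncc(-c4cccc(OC)c4)cc23)c1F` differs from compound 2 by 3-methoxyphenyl in place of 2-chlorophenyl on an aromatic carbon. Going by the values given here, the only measured step, from compound 1 to compound 2, also alters this phenyl group, and it produced no change beyond the scatter. On that basis compound 3 is expected to remain close to compound 2, with a step of a number 2.3 percentage points lower from compound 2 to compound 3 (within the scatter) that is expected to stay within the scatter. Compound 3 is therefore estimated at 7% in this assay, within a range from 1% to 30%.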

Compound 3, a percentage reported as activity, at one concentration (the size of the read-out at that concentration, not a potency): 6.3%
Compound 3: the middle estimate sits 0.7 percentage points above what was measured, and the stated range covers the measured number.
By their numbers in this assay, from the lowest: compounds 1, 3 and 2 (each within the scatter of the next).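

Compound 3 shows that a phenyl group at this aromatic carbon can carry an oxygen-linked substituent as well as a chlorine without the read-out separating the compounds: in this assay, the swap of 2-chlorophenyl for 3-methoxyphenyl gives a number 3 percentage points lower from compound 2 to compound 3 (within the scatter), and methoxy in place of hydrogen gives a number 3.9 percentage points higher from compound 1 to compound 3 (within the scatter). Across these three compounds, neither the substituent nor its place on the phenyl ring produces a difference that can be read, although chloro and methoxy are each seen at only one ring position. Nothing available here offers an explanation for these values.

From the compounds shown here alone, what remains open is whether a larger or charged substituent on this phenyl ring, such as an amine or a carboxylic acid, would leave the read-out equally unmoved. Going by these compounds, it is also open whether a morpholine in place of the whole phenyl group would do so.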